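Isopropyl to propyl on the nitrogen

The source may report more compounds than this note shows. Statements on the series, on what has been measured and on what is new or still open speak of the compounds shown alone.

Compound 1 `Cc1ccc(OCCCN(Cc2ccc(C(=O)NO)cc2)c2ncc(-c3ccc(C)cc3)s2)cc1` gives 12600 nM here
Compound 2 `Cc1ccc(-c2cnc(N(Cc3ccc(C(=O)NO)cc3)C(C)C)s2)cc1` gives 7800 nM here

Both values come from a functional assay on HCT-116 cells (Homo sapiens) for antiproliferative activity, read by MTT assay, with a stated time of 48 h (a lower number here means a stronger inhibitor of growth, a higher number a weaker inhibitor of growth), and they lie within the scatter of each other, so compound 2 cannot be ranked against compound 1. Compound 3 `CCCN(Cc1ccc(C(=O)NO)cc1)c1ncc(-c2ccc(C)cc2)s1` is still unmeasured. It carries propyl in place of isopropyl on a nitrogen on an aromatic ring, and the rest of the structure is that of compound 2.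

Among the measured compounds shown here, only one measured step bears on this place: isopropyl in place of 3-(4-methylphenoxy)propyl (a 1.6-fold lower number from compound 1 to compound 2 (0.21 log units; within the scatter)), and it stays within the scatter. It is a single step and involves a different pair of groups. The data hold no direct comparison of propyl with isopropyl. On that thin basis, no step beyond the scatter is expected in this assay in either direction. The estimated step is small (a 1.0-fold higher number from compound 2 to compound 3 (0.01 log units; within the scatter)). Compound 3 is expected at 8000 nM, with an estimated range of 3800 nM to 16000 nM for the measurement.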

Compound 3, concentration for 50% growth inhibition: 5800 nM
Compound 3: middle estimate off by 1.4-fold (0.14 log units), on the high side; the measured number falls inside the stated range.
By their numbers in this assay, from the lowest: compounds 3, 2 and 1 (each within the scatter of the next, the first and the last beyond it).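

Propyl and isopropyl on this nitrogen now have a direct comparison in this assay (a 1.3-fold lower number from compound 2 to compound 3 (0.13 log units; within the scatter)), and with 3 heavy atoms (3 carbon) on each side of the change, compound 2 and compound 3 cannot be ranked against each other. Among the compounds shown here, the removal of the 4-methylphenoxy group from the end of the propyl chain gives the only step beyond the scatter among the three compounds (a 2.2-fold lower number from compound 1 to compound 3 (0.34 log units; beyond the scatter)), a modest one, while compound 2, with isopropyl, stays within the scatter of both neighbours, so the series still shows no clear separation between the two small groups and the long chain on this nitrogen. No measurement at hand explains either step.

Going by these compounds, whether the modest gain on losing 4-methylphenoxy would hold with another group at the end of the propyl chain, such as an amine or a carboxylic acid, remains open. Also open, on these data alone, is whether methyl, butyl or a longer unbranched chain on the same nitrogen would move the number in this assay beyond the scatter of compound 3.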